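Swapping furan-3-yl for thiophen-3-yl in compound 2

The source may report more compounds than this note shows. Statements on the series, on what has been measured and on what is new or still open speak of the compounds shown alone.

In a functional assay on T47D cells (Homo sapiens) for inhibition, read by CCK-8 assay and cell counting, with a stated time of 2 days (a higher number here means a weaker inhibitor, a lower number a stronger inhibitor), compound 1 (`O=C(/C=C/c1ccco1)c1ccc(OCC2CO2)cc1`) gives 17700 nM and compound 2 (`O=C(/C=C/c1ccoc1)c1ccc(OCC2CO2)cc1`) gives 20600 nM on the same read-out. Among the compounds with values here, the step of a 1.2-fold higher number from compound 1 to compound 2 (0.07 log units; within the scatter) lies within the scatter, so compound 2 stands level with compound 1, the only other compound measured. Compound 3 (`O=C(/C=C/c1ccsc1)c1ccc(OCC2CO2)cc1`) differs from compound 2 by thiophen-3-yl in place of furan-3-yl on a double-bonded chain carbon bound to a double-bonded chain carbon and in nothing else. Within the data shown here, no measured step exchanges furan for thiophene, so the data offer no direct guide. Among the measured compounds shown here, the only measured step at this place, furan-3-yl in place of furan-2-yl, stayed within the scatter. On that slender evidence, no step beyond the scatter is expected in this assay for this change. The expected change is a 1.1-fold lower number from compound 2 to compound 3 (0.06 log units; within the scatter) at the middle of the estimate. Compound 3 is estimated at 18000 nM with an expected range from 9000 nM to 35000 nM as its likely span.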

Compound 3, half-maximal inhibitory concentration: 10600 nM
The estimate for compound 3 lay 1.7-fold (0.23 log units) above the measured number, within the range that was stated.
By their numbers in this assay, from the lowest: compounds 3, 1 and 2 (each within the scatter of the next).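

In this assay, thiophen-3-yl in place of furan-3-yl gives a 1.9-fold lower number from compound 2 to compound 3 (0.29 log units; within the scatter) at this double-bonded chain carbon, so exchanging the ring oxygen for a ring sulfur produces no step beyond the scatter. Set against furan-2-yl, the same group gives a 1.7-fold lower number from compound 1 to compound 3 (0.22 log units; within the scatter) at this place, so all three five-membered aromatic rings shown stand level here, whichever hetero atom they carry. Nothing measured in the material shown accounts for how closely these numbers lie.

All the variation shown is confined to these rings, so it remains open whether a phenyl ring, a pyridine ring or an amine at this place would move the number beyond the scatter. From the compounds shown here alone, it is equally open whether a methyl group or a chlorine on the thiophen-3-yl would do so.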